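Trading a Methyl Ester for an Acid on Compound 2

The source may report more compounds than this note shows. Statements on the series, on what has been measured and on what is new or still open speak of the compounds shown alone.

Compound 2 `COC(=O)c1ccccc1OCc1oc(-c2cccc(OC)c2)nc1C` is tested in an assay on cells for antagonist activity at vitamin D3 receptor (Homo sapiens), read by a luciferase reporter (on this read-out lower numbers stand for stronger inhibition and higher numbers for weaker inhibition), where compound 2 gives 15400 nM. Its two companions are compound 1 `COC(=O)c1ccccc1OCc1oc(-c2ccccc2OC)nc1C`, which gives 20200 nM in this assay, and compound 3 `COC(=O)CCc1ccc(OCc2oc(-c3ccccc3OC)nc2C)cc1`, which gives 13600 nM. Among the measured compounds shown here, the only single-point step among them, a 1.3-fold lower number from compound 1 to compound 2 (0.12 log units; within the scatter), leaves all three within the scatter of one another, so no ranking can be drawn.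

Compound 4 `COc1cccc(-c2nc(C)c(COc3ccccc3C(=O)O)o2)c1` differs from compound 2 by hydrogen in place of methyl on an oxygen next to a carbonyl group. For the measured compounds named here, no measured pair touches this part of the molecule; the step from compound 1 to compound 2 concerns the methoxyphenyl ring and offers no guide here. With nothing to suggest a shift either way, the expected step is a 1.0-fold lower number from compound 2 to compound 4 (0.01 log units; within the scatter). Compound 4 is therefore estimated at 15000 nM, plausibly between 4000 nM and 55000 nM.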

Compound 4, half-maximal inhibitory concentration in the vitamin D3 receptor assay: > 33000 nM
Compound 4: a limit, no number (the forecaster's own chance of this, stated with the estimate: 25%); middle value at least 2.2-fold (0.34 log units) from the limit.
By their numbers in the vitamin D3 receptor assay, from the lowest: compounds 3, 2 and 1 (each within the scatter of the next). At a limit, above all of these: compound 4.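

Among the compounds shown here, in the vitamin D3 receptor assay, going from methoxycarbonyl to carboxy gives an at least 2.1-fold higher number from compound 2 to compound 4 (0.33 log units; beyond the scatter), the first step here to pass the scatter, so this position responds where the methoxyphenyl change did not. Compound 4 gives > 33000 nM in the vitamin D3 receptor assay, which is a limit and not a number. In a physicochemical assay for solubility, tested at 500 uM (on this read-out lower numbers stand for lower solubility and higher numbers for higher solubility), compound 2 gives 52800 nM and compound 4 gives 264000 nM. In the physicochemical assay, the same change goes with higher solubility: the measured solubility of compound 2, 52800 nM, and of compound 4, 264000 nM, a 5.0-fold higher number (0.70 log units; beyond the scatter)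

As far as these compounds go, how much inhibition compound 4 really loses stays open. So does whether an amide or an ethyl ester at this place would keep the inhibition of compound 2 while raising solubility.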